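From Bromo to Nitro in a Small Antiproliferative Series

The source may report more compounds than this note shows. Statements on the series, on what has been measured and on what is new or still open speak of the compounds shown alone.

Of the compounds shown here, three have been tested so far, and they give a first sense of how strongly this family slows the growth of liver cancer cells. In a functional assay on HepG2 cells (Homo sapiens) for antiproliferative activity, read by fluorescence and resazurin assay, with a stated time of 48 h (on this read-out lower numbers stand for stronger inhibition and higher numbers for weaker inhibition), compound 2 `O=C(N/N=C/c1ccncc1)c1cc2cc(Br)ccc2oc1=O` gives 4890 nM, the lowest of the three numbers. Compound 1 `CCOc1ccc2nc(Cl)c(/C=N/NC(=O)c3cc4cc([N+](=O)[O-])ccc4oc3=O)cc2c1` gives 18100 nM and compound 3 `CCOc1ccc(NC(=O)c2cc3ccc(O)cc3oc2=O)cc1` gives 17300 nM, and each of these lies above compound 2 by more than the usual scatter.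

The next compound to be tested, compound 4 `O=C(N/N=C/c1ccncc1)c1cc2cc([N+](=O)[O-])ccc2oc1=O`, keeps all of compound 2 except for one group: nitro in place of bromo on an aromatic carbon. For the measured compounds named here, no two measured compounds differ in only one place, so the size of such a swap has not been seen directly. Going by the values given here, the only hint is compound 1, which also carries a nitro group and gives 18100 nM, although it differs from compound 2 in much else besides. A modest rise towards weaker inhibition is therefore expected, perhaps not beyond the scatter. The expected change is a 1.6-fold higher number from compound 2 to compound 4 (0.21 log units; within the scatter). Compound 4 is estimated at 8000 nM, with an expected range from 2500 nM to 25000 nM.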

Compound 4, half-maximal inhibitory concentration: 15800 nM
For compound 4 the middle estimate is 2.0-fold (0.30 log units) below the measured one, within the range that was stated.
By their numbers in this assay, from the lowest: compound 2; then compounds 4, 3 and 1 (each within the scatter of the next).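

For the compounds shown here, with everything else held constant, the swap of bromo for nitro gives a 3.2-fold higher number from compound 2 to compound 4 (0.51 log units; beyond the scatter) in this assay, the first direct reading of a single change. It shows that the group on this aromatic carbon, on the six-membered aromatic ring of carbon only, can by itself shift the read-out, so this position is not indifferent to what it carries, and here bromo goes with the stronger inhibition. No measured property of these compounds is available to explain the size of this step.

Going by these compounds alone, with only two groups seen at this carbon, a single step gives a direction for this pair and no trend, so what a hydrogen, a chloro, a methoxy or an amine would give in the same place remains open. Also open, on these data alone, is whether the same swap would produce a step of similar size on a different core, such as that of compound 1, or with a different group in place of the rest of compound 2.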